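Swapping a Methyl for Methylsulfanyl on a Nucleoside Core

A few compounds are considered here, and "the series" means these few. Any claim that something is new, unique, unknown or untested is made for them only; others in the source may bear on it.

For the measured compounds named here, compound 1 `C#Cc1cn([C@@H]2O[C@H](CO)[C@@H](O)[C@H]2O)c2ncnc(C)c12` is the only compound here with a measured number: in a functional assay on K562 cells (Homo sapiens), read by MTT assay, with a stated time of 72 h (a higher number here means a weaker inhibitor, a lower number a stronger inhibitor), compound 1 gives 110 nM. Compound 2 `Cc1ncnc2c1c(-c1cc3ccccc3o1)cn2[C@@H]1O[C@H](CO)[C@@H](O)[C@H]1O` carries a 1-benzofuran-2-yl in place of the ethynyl, and in this assay compound 2 reaches only a limit of the assay, > 20000 nM. Compound 3 `Cc1ncnc2c1c(-c1ccoc1)cn2[C@@H]1O[C@H](CO)[C@@H](O)[C@H]1O` carries a furan-3-yl instead, and in this assay compound 3 likewise reaches only a limit, > 20000 nM. Both replacements of the ethynyl are large losses: an at least 180-fold higher number from compound 1 to compound 2 (2.25 log units; beyond the scatter) and an at least 180-fold higher number from compound 1 to compound 3 (2.25 log units; beyond the scatter), with the limit of > 20000 nM in this assay, at which 2 of the 3 values shown sit, marking where those two compounds sit. The step from compound 2 to compound 3 cannot be read from two limits.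

Compound 4 `C#Cc1cn([C@@H]2O[C@H](CO)[C@@H](O)[C@H]2O)c2ncnc(SC)c12` keeps the ethynyl and changes a different place: methylsulfanyl in place of methyl on an aromatic carbon. Going by the values given here, none of the measured steps touches this position, so they give no direct guide; they only show that the ethynyl itself should stay. A step within the usual scatter is therefore expected, a 1.4-fold higher number from compound 1 to compound 4 (0.13 log units; within the scatter), and compound 4 is estimated at 150 nM in this assay, between 40 nM and 600 nM.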

Compound 4, half-maximal inhibitory concentration: 70 nM
Beside the measured number, compound 4's estimate is 2.1-fold (0.33 log units) above it, and the stated range covers the measured number.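

Until now, every change had been made at the ethynyl. This one sits on the aromatic carbon next to the ring nitrogen, and in this assay methylsulfanyl in place of methyl gives a 1.6-fold lower number from compound 1 to compound 4 (0.20 log units; within the scatter), so the two compounds cannot be told apart. This position therefore accepts either group with no readable change in this assay, whereas both replacements of the ethynyl were large losses. Nothing measured here explains why methyl and methylsulfanyl read alike.

The compounds shown leave open how this position responds to an amine, a methoxy group or a longer sulfur-bearing chain such as ethylsulfanyl. They also leave open whether methylsulfanyl on the shared core reads the same way when the ethynyl is replaced by another group.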